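The source may report more compounds than this note shows. Statements on the series, on what has been measured and on what is new or still open speak of the compounds shown alone.

Values in a functional assay on NCI-H460 cells (Homo sapiens) for antiproliferative activity, read by MTT assay, with a stated time of 48 h; a lower number here means a stronger inhibitor, a higher number a weaker inhibitor:
- Compound 1 `COc1ccc(-c2nc3cccc(-c4cc(OC)c(OC)c(OC)c4)c3o2)cc1OC`: > 25000 nM, a limit
- Compound 2 `COc1ccc(-c2nc3cccc(-c4cc(OC)c(OC)c(OC)c4)c3o2)cc1F`: 2800 nM
- Compound 3 `COc1cc(-c2cccc3nc(-c4cccc(Cl)c4)oc23)cc(OC)c1OC`: > 25000 nM, a limit

Compound 3 gives no number in this assay, only the limit > 25000 nM. It shares that limit with compound 1, as the limit of > 25000 nM in this assay, at which 2 of the 3 values shown sit, shows, and only compound 2 has a measured value.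

Compound 4 `COc1cc(-c2cccc3nc(-c4ccc(Cl)cc4)oc23)cc(OC)c1OC` differs from compound 3 in one place, with 4-chlorophenyl in place of 3-chlorophenyl on an aromatic carbon of a five-membered aromatic ring with 1 nitrogen and 1 oxygen (4-chlorophenyl in place of 3-chlorophenyl on an aromatic carbon). Going by the values given here, no measured step makes this exact exchange. The closest evidence is an at least 8.9-fold higher number from compound 2 to compound 3 (0.95 log units; beyond the scatter), where 3-chlorophenyl replaced 3-fluoro-4-methoxyphenyl at the same place. In addition, an at least 8.9-fold lower number from compound 1 to compound 2 (0.95 log units; beyond the scatter) came with fluoro in place of methoxy. Both steps lie beyond the scatter, so a small change on this aryl group can matter. The third comparison, a step that the two limits leave unreadable from compound 1 to compound 3, cannot be read between two limits.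

A modest move towards a lower number is therefore expected, although another limit remains quite possible. The expected change is an at least 1.6-fold lower number from compound 3 to compound 4 (0.22 log units; that floor lies within the scatter). Compound 4 is estimated at 15000 nM, with an expected range of 4000 nM to 40000 nM.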

Compound 4, half-maximal inhibitory concentration: > 25000 nM
Compound 4 was reported as a limit; the forecaster's own chance of this, stated with the estimate: 50%; middle value at least 1.6-fold (0.22 log units) from the limit.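

With 4-chlorophenyl in place of 3-chlorophenyl at this aryl group, the reading in this assay stays at the limit of the assay, so neither chlorophenyl group gives a measured value, and the steps from compound 3 and from compound 1 to compound 4 cannot be read, since both ends of each are limits. Going by these compounds alone, the one readable new step is an at least 8.9-fold higher number from compound 2 to compound 4 (0.95 log units; beyond the scatter), with 4-chlorophenyl in place of 3-fluoro-4-methoxyphenyl, so both chlorophenyl groups now stand beyond the scatter from the only measured compound on the weaker side. Compound 2 thus remains the only compound here with a measured value, and the limit has become the most common reading: the limit of > 25000 nM in this assay, at which 3 of the 4 values shown sit.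

Going by these compounds, how far compound 3 and compound 4 lie past that limit stays unknown, so whether the two chlorophenyl groups differ at all cannot be said. Also open, on these data alone, is whether 3-fluorophenyl, 4-methoxyphenyl or an aminophenyl group at this place would give a measured value, which would show whether the fluoro and methoxy groups of compound 2 are each needed.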